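A few compounds are considered here, and "the series" means these few. Any claim that something is new, unique, unknown or untested is made for them only; others in the source may bear on it.

Three measured compounds share one core and differ only in the ring hung on a double-bonded chain carbon bound to a double-bonded chain carbon. Compound 1 `COc1ccc(C(=O)/C=C/c2cccc(F)c2)c2c1C=CC(C)(C)O2` carries a 3-fluorophenyl there, compound 2 `COc1ccc(C(=O)/C=C/c2ccccn2)c2c1C=CC(C)(C)O2` a pyridin-2-yl and compound 3 `COc1ccc(C(=O)/C=C/c2ccc(Cl)cc2)c2c1C=CC(C)(C)O2` a 4-chlorophenyl. In a functional assay on HepG2 cells (Homo sapiens) for antiproliferative activity, read by MTT assay, with a stated time of 24 h (a higher number here means a weaker inhibitor, a lower number a stronger inhibitor), compound 1 gives > 10000 nM, which is a limit of the assay and not a number. In this assay compound 2 gives 5760 nM. Compound 3 gives > 10000 nM in this assay, again a limit and not a number. So compound 3 stands at the limit rather than at a number: the move an at least 1.7-fold higher number from compound 2 to compound 3 (0.23 log units; that floor lies within the scatter) has only a floor, and the move a step that the two limits leave unreadable from compound 1 to compound 3 cannot be read, since (the limit of > 10000 nM in this assay, at which 2 of the 3 values shown sit).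

The unmeasured compound 4 `COc1ccc(C(=O)/C=C/c2ccc(O)c(Br)c2)c2c1C=CC(C)(C)O2` changes the same place: 3-bromo-4-hydroxyphenyl in place of 4-chlorophenyl on a double-bonded chain carbon bound to a double-bonded chain carbon. Going by the values given here, no measured step swaps one carbon ring for another bearing a hydroxyl and a bromine, so the only guidance is that every change at this place among compounds 1, 2 and 3 left the number near the limit. A step of modest size, if any, is therefore expected in this assay, with the direction uncertain; the expected step is an at least 1.2-fold lower number from compound 3 to compound 4 (0.09 log units; that floor lies within the scatter). Compound 4 is estimated at 8000 nM, within 2500 nM to 25000 nM.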

Compound 4, half-maximal inhibitory concentration: > 10000 nM
Compound 4: no number, only a limit (the forecaster's own chance of this, stated with the estimate: 45%); at least 1.2-fold (0.09 log units) between middle value and limit.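

Adding a hydroxyl and a bromine to the ring at this place, as 3-bromo-4-hydroxyphenyl in place of 4-chlorophenyl, does not bring a number into reach in this assay: compound 4 gives > 10000 nM, a limit of the assay and not a number. Going by these compounds alone, the only readable step is an at least 1.7-fold higher number from compound 2 to compound 4 (0.23 log units; that floor lies within the scatter), which is a floor alone, and the steps to compound 4 from the two other compounds with a carbon ring cannot be read. A carbon ring with a hydrogen-bond donor now sits with the two halogen-bearing carbon rings, so all three carbon rings shown end at the limit and only compound 2, with its pyridin-2-yl, goes against this pattern: the limit of > 10000 nM in this assay, at which 3 of the 4 values shown sit.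

As far as these compounds go, how far compound 1, compound 3 and compound 4 lie past that limit stays open, so no order among them can be given, nor can their real distance from compound 2. Also open, from the compounds shown here alone, is whether a phenyl ring bearing an amine or a carboxylic acid, or a pyridin-4-yl ring, would give a number rather than a limit at this place.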